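Secondary amine with acetamidobenzyl group at the hydroxypiperidine side chain

This account rests on a few compounds, and the source may have more. Where it says the series, first, only, none or still open, it means among the compounds named here.

Measured compounds in a functional assay on CHO cells for agonist activity at 5-hydroxytryptamine receptor 1D (Homo sapiens), read by GTPgammaS binding; a higher number here means that more compound is needed for the effect, a lower number that less compound is needed:
compound 1 `CN(CC(C)(C)C)CC1(O)CCN(CCCc2c[nH]c3ccc(-n4cnnc4)cc23)CC1`, 1.6 nM;
compound 2 `CC(C)(C)OC(=O)NCC1(O)CCN(CCCc2c[nH]c3ccc(-n4cnnc4)cc23)CC1`, 9.7 nM;
compound 3 `CN(Cc1ccccc1)CC1(O)CCN(CCCc2c[nH]c3ccc(-n4cnnc4)cc23)CC1`, 3.8 nM.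

Compound 3 stands second of the three, with compound 1 nearest and compound 2 furthest. Compound 4 `CC(=O)Nc1ccc(CNCC2(O)CCN(CCCc3c[nH]c4ccc(-n5cnnc5)cc34)CC2)cc1` differs from compound 3 by (4-acetamidobenzyl)amino in place of benzyl(methyl)amino on a saturated chain carbon bound to a saturated ring carbon. For the measured compounds named here, two measured steps bear on this: a 2.4-fold higher number from compound 1 to compound 3 (0.38 log units; beyond the scatter), and a 2.6-fold lower number from compound 2 to compound 3 (0.41 log units; beyond the scatter), both modest. Exchanging the terminal group on the amine nitrogen therefore moved the number only modestly, while a less basic, donor-bearing group at this carbon weakened the effect somewhat. For compound 4 a modest rise in this assay is expected, a 1.8-fold higher number from compound 3 to compound 4 (0.27 log units; within the scatter). Compound 4 is estimated at 7 nM, within 1.8 nM to 28 nM.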

Compound 4, concentration for half-maximal effect: 14 nM
Beside the measured number, compound 4's estimate is 2.0-fold (0.30 log units) below it; low and high end bracket the measured number.
By their numbers in this assay, from the lowest: compound 1; then compound 3; then compounds 2 and 4 (each within the scatter of the next).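

In this assay, (4-acetamidobenzyl)amino on this saturated chain carbon gives a 3.7-fold higher number from compound 3 to compound 4 (0.57 log units; beyond the scatter) and an 8.8-fold higher number from compound 1 to compound 4 (0.94 log units; beyond the scatter), so the tolerance seen among the earlier amines has a limit with this larger group. With a 1.4-fold higher number from compound 2 to compound 4 (0.16 log units; within the scatter), 4-acetamidobenzyl and tert-butoxycarbonyl on the amine nitrogen cannot be told apart here. No measurement available here explains these steps.

As far as these compounds go, the step from compound 3 changes the methyl and the acetamido group together, so their shares remain open. A plain benzylamino group or methyl(4-acetamidobenzyl)amino would separate them.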